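Replacing dimethoxyphenyl with hydroxyphenyl on the pyrazolopyridine core

The source may report more compounds than this note shows. Statements on the series, on what has been measured and on what is new or still open speak of the compounds shown alone.

In a functional assay on CCRF-CEM cells (Homo sapiens) for antiproliferative activity, read by resazurin assay, with a stated time of 72 h (on this read-out higher numbers stand for weaker inhibition and lower numbers for stronger inhibition), three members of this series have been measured. Compound 1 `COc1ccc(-c2nc3c(c(-c4ccccc4)nn3-c3ccccc3)c(-c3ccc(O)cc3)c2C#N)cc1` gives 6700 nM. Compound 3 `COc1cc(-c2c(C#N)c(-c3cccs3)nc3c2c(-c2ccccc2)nn3-c2ccccc2)ccc1O` gives 37300 nM. Compound 2 `COc1ccc(-c2c(C#N)c(-c3ccccc3)nc3c2c(-c2ccccc2)nn3-c2ccccc2)cc1OC` stands apart: its result is not a number but a limit of the assay, > 25000 nM, and it is the only one of the three that ends at that limit, as the evidence the limit of > 25000 nM in this assay, at which 1 of the 3 values shown sits, shows. On the numbers shown, compound 2 therefore sits at the weak end of the measured set.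

Compound 4 `N#Cc1c(-c2ccccc2)nc2c(c(-c3ccccc3)nn2-c2ccccc2)c1-c1ccc(O)cc1` has not yet been measured in this assay. It differs from compound 2 in one place: 4-hydroxyphenyl in place of 3,4-dimethoxyphenyl on an aromatic carbon. Within the data shown here, no step between two measured compounds describes this exact change. Compound 1, which also carries a 4-hydroxyphenyl group, gives 6700 nM, and compound 3, which carries a hydroxyl on that ring as well, gives 37300 nM; both are numbers rather than limits. On that basis compound 4 is expected to move from the limit toward a measurable value, a step of an at least 2.0-fold lower number from compound 2 to compound 4 (0.31 log units; beyond the scatter) in the direction of stronger inhibition. Compound 4 is estimated at 12000 nM, with a range from 3500 nM to 40000 nM.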

Compound 4, half-maximal inhibitory concentration: 33400 nM
Beside the measured number, compound 4's estimate is 2.8-fold (0.44 log units) below it; the range from low to high includes it.
By their numbers in this assay, from the lowest: compound 1; then compounds 4 and 3 (each within the scatter of the next).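

Compound 4 shows that 4-hydroxyphenyl at this position, opposite the ring nitrogen, does not by itself give a value at the level of compound 1, even though both compounds carry that group. Among these compounds, the pair differs only in hydrogen in place of methoxy on an aromatic carbon, and in this assay that single change gives a 5.0-fold higher number from compound 1 to compound 4 (0.70 log units; beyond the scatter), so in this pair the methoxy group counts for more than the earlier compounds could show. The change from 3,4-dimethoxyphenyl to 4-hydroxyphenyl itself has no readable size, because compound 2 remains a limit of the assay and not a number: the limit of > 25000 nM in this assay, at which 1 of the 4 values shown sits.

The compounds shown leave open how much, if anything, this swap changes the result, since neither end of it has been tied to a number on the 3,4-dimethoxyphenyl side. They also leave open whether the hydroxyl is needed on that ring at all, as a plain phenyl group or an amine or carboxylic acid in its place would be the test of that.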